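From phenoxy to ethyl: estimating a cytotoxicity step

This account rests on a few compounds, and the source may have more. Where it says the series, first, only, none or still open, it means among the compounds named here.

Three close relatives have been measured in a functional assay on KB 3-1 cells (Homo sapiens) for cytotoxicity, read by MTT assay, with a stated time of 72 h (on this read-out higher numbers stand for weaker inhibition and lower numbers for stronger inhibition), and differ in a single group on an aromatic carbon. Compound 1 `O=C1Nc2ccccc2/C1=N/NC(=S)Nc1ccc(Cl)cc1` gives 13400 nM with chloro, compound 2 `O=C1Nc2ccccc2/C1=N/NC(=S)Nc1ccc(F)cc1` gives 14200 nM with fluoro, and compound 3 `O=C1Nc2ccccc2/C1=N/NC(=S)Nc1ccc(Oc2ccccc2)cc1` gives 5720 nM with phenoxy, the lowest number of the three and so the strongest inhibition here.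

Compound 4 `CCc1ccc(NC(=S)N/N=C2\C(=O)Nc3ccccc32)cc1` keeps the shared core but has ethyl in place of phenoxy on an aromatic carbon and still awaits measurement. Going by the values given here, three measured steps bear on this change. Swapping chloro for fluoro gives a 1.1-fold higher number from compound 1 to compound 2 (0.03 log units; within the scatter) and so shows no real change. Bringing in phenoxy gives a 2.3-fold lower number from compound 1 to compound 3 (0.37 log units; beyond the scatter) and a 2.5-fold lower number from compound 2 to compound 3 (0.39 log units; beyond the scatter) as two modest steps.

Among the compounds with values here, no ethyl compound has been measured, so any forecast is uncertain. Ethyl has no ring, so much of the gain seen in compound 3 (5720 nM) is expected to be lost. The expected change is a 2.1-fold higher number from compound 3 to compound 4 (0.32 log units; beyond the scatter) as a modest move towards the numbers of the chloro and fluoro compounds. For compound 4 the estimated value is 12000 nM with an expected range from 6000 nM to 22000 nM in this assay once it is tested.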

Compound 4, half-maximal inhibitory concentration: 4050 nM
The estimate for compound 4 lay 3.0-fold (0.47 log units) above the measured number, and the stated range ends above it.
By their numbers in this assay, from the lowest: compounds 4 and 3 (each within the scatter of the next); then compounds 1 and 2 (each within the scatter of the next).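

In this assay, ethyl in place of phenoxy gives a 1.4-fold lower number from compound 3 to compound 4 (0.15 log units; within the scatter), so the two groups cannot be told apart here, and the aromatic ring of phenoxy is not required for a low number at this position. Ethyl also gives lower numbers than the two halogen compounds, with a 3.5-fold lower number from compound 2 to compound 4 (0.54 log units; beyond the scatter) and a 3.3-fold lower number from compound 1 to compound 4 (0.52 log units; beyond the scatter), so two quite different groups, phenoxy and ethyl, both sit apart from fluoro and chloro, though only by modest steps. Nothing available here gives a reason for this shared shift.

What remains open is how far this result extends beyond ethyl and phenoxy, since the compounds shown include neither a smaller group such as methyl nor a longer chain such as butyl. An amine or a carboxylic acid at the same place would show whether the number stays low with groups of a very different kind, or returns to the level of the fluoro and chloro compounds.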